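The compounds below may be only part of what the source reports. "The series", "measured", "known", "first", "only" and "open" are said of these compounds alone.

Of the compounds shown here, two sharing one core have been measured in a functional assay with Homo sapiens as the target; a higher number here means a weaker inhibitor, a lower number a stronger inhibitor. Compound 1, `COc1cccc(NC(=O)c2cnn(-c3ccc(F)cc3)c2C)c1`, gives 3700 nM in this assay. Compound 2, `COc1ccc(-n2ncc(C(=O)Nc3ccc(C(F)(F)F)cc3)c2C)cc1`, gives 340 nM in this assay. Compound 2 thus has the lower of the two numbers, and compound 1 stands at a higher number, a gap beyond the scatter. Since these two compounds differ in more than one place, their values show only how far apart they lie, not which change accounts for the gap.

Compound 3, `COc1cccc(-n2ncc(C(=O)Nc3ccc(C(F)(F)F)cc3)c2C)c1`, has not yet been measured. It is compound 2 with the same atoms joined differently: 3-methoxyphenyl in place of 4-methoxyphenyl on an aromatic nitrogen. Among the measured compounds shown here, no measured pair shows this change on its own, so its effect is not known from the numbers at hand. The change keeps every atom and alters only how they are joined, so the expected step from compound 2 to compound 3 in this assay is a 1.6-fold higher number from compound 2 to compound 3 (0.21 log units; within the scatter), within the scatter or at most a modest weakening. Compound 3 is therefore expected to give about 550 nM in this assay, with a likely range from 150 nM to 2000 nM.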

Compound 3, half-maximal inhibitory concentration: 2500 nM
Estimate against measurement, compound 3: 4.5-fold (0.66 log units) below; the whole stated range lies below it.
By their numbers in this assay, from the lowest: compound 2; then compounds 3 and 1 (each within the scatter of the next).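

Among the compounds shown here, putting 3-methoxyphenyl in place of 4-methoxyphenyl on the aromatic nitrogen gives, in this assay, a 7.4-fold higher number from compound 2 to compound 3 (0.87 log units; beyond the scatter) and thereby provides the first comparison here in which only one place differs. It shows that this position responds clearly to where the methoxy group sits on the attached group, even though the atoms stay the same and the counted features of the two groups match, with the same numbers of hydrogen-bond donors and acceptors and no net charge. The data at hand offer no measurement that explains this difference.

The compounds shown leave open whether other groups on the aromatic nitrogen would keep the lower number of compound 2, for example a phenyl carrying a hydroxyl group, an amine or a longer ethoxy chain in place of the methoxy group. They also leave open whether the same preference holds when the trifluoromethyl-bearing group on the amide is replaced, since this single pair tests the change with only that one partner.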